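This account rests on a few compounds, and the source may have more. Where it says the series, first, only, none or still open, it means among the compounds named here.

Measured compounds:
- compound 1 `COC/C1=C/C[C@](C)(CCC=C(C)C)/C=C/[C@@H](OC(=O)C=C(C)C)[C@](C)(OC)/C=C/C1=O`: 9380 nM
- compound 2 `CC(C)=CCC[C@]1(C)/C=C/[C@@H](OC(=O)C=C(C)C)[C@](C)(O)/C=C/C(=O)/C(CN(C)C)=C\C1`: 820 nM
- compound 3 `CC(C)=CCC[C@]1(C)/C=C/[C@@H](OC(=O)C=C(C)C)[C@](C)(O)CCC(=O)/C(CO)=C\C1`: > 40000 nM, a limit of the assay and not a number

In a functional assay on SMMC-7721 cells (Homo sapiens) for antiproliferative activity, read by MTT assay, with a stated time of 48 h (a lower number here means a stronger inhibitor, a higher number a weaker inhibitor), compound 2 gives 820 nM, the lowest of the two numbers shown. The nearest number is that of compound 1, which in this assay gives 9380 nM, and the gap between the two lies beyond the scatter. Compound 3 reaches only (the limit of > 40000 nM in this assay, at which 1 of the 3 values shown sits), so no number is available for it.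

Compound 4 `CC(C)=CCC[C@]1(C)/C=C/[C@@H](OC(=O)C=C(C)C)[C@](C)(O)/C=C/C(=O)/C(C(=O)N(C)C)=C\C1` differs from compound 2 at one place: dimethylcarbamoyl in place of (dimethylamino)methyl on a double-bonded ring carbon. Within the data shown here, no pair of measured compounds shows the effect of this particular change, so the step can only be judged from the three values above, which offer no direct precedent for the exchange of one group for the other.

Compound 4 is expected to be weaker than compound 2 in this assay, with a step of a 4.3-fold higher number from compound 2 to compound 4 (0.63 log units; beyond the scatter) that is estimated to lie beyond the scatter. The value for compound 4 in this assay is estimated at 3500 nM, within a range from 800 nM to 15000 nM.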

Compound 4, half-maximal inhibitory concentration: 3670 nM
For compound 4 the middle estimate is 1.0-fold (0.02 log units) below the measured one, within the range that was stated.
By their numbers in this assay, from the lowest: compound 2; then compound 4; then compound 1. At a limit, above all of these: compound 3.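

In this assay, dimethylcarbamoyl in place of (dimethylamino)methyl on the double-bonded ring carbon gives a 4.5-fold higher number from compound 2 to compound 4 (0.65 log units; beyond the scatter), which shows that a change at this position alone can move the number. With this exchange, compound 4 still gives a measurable value of 3670 nM, so the (dimethylamino)methyl group is not required for a measurable value in this series. No evidence shown here accounts for the size of this step.

The compounds shown leave open how other groups on this carbon would read, such as a morpholinomethyl group, a carboxylic acid or a longer chain ending in a dimethylamino group. They also leave open whether the same exchange would give a step of similar size with a methoxy group in place of the hydroxy group.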